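The source may hold more compounds than are shown below. What is called first, only, known or untested is meant among the compounds shown, and "the series" means these compounds.

Working notes on the series. Compound 1 `O=C(Nc1ccccc1Br)c1ccc2cccc(O)c2n1` gives 2.5 in a physicochemical assay for lipophilicity, read by HPLC; a lower number here means a more polar compound, a higher number a more lipophilic compound. Compound 2 `O=C(Nc1ccc(Br)cc1)c1ccc2cccc(O)c2n1` gives 2.5 in this assay, and compound 3 `O=C(Nc1ccccc1C(F)(F)F)c1ccc2cccc(O)c2n1` gives 2.5 in this assay. The two cores differ by 4-bromophenyl in place of 2-bromophenyl on an amide-type nitrogen, with a step of no change at the digits printed from compound 1 to compound 2 (within the scatter). The change trifluoromethyl in place of bromo on an aromatic carbon gives a step of no change at the digits printed from compound 1 to compound 3 (within the scatter). Compound 4 `O=C(Nc1ccc(C(F)(F)F)cc1)c1ccc2cccc(O)c2n1` is still to be measured in this assay. Its difference from compound 2 is trifluoromethyl in place of bromo on an aromatic carbon; this is the same kind of change as that from compound 1 to compound 3, the place now being para to a large group rather than ortho to a large group. Because no change at the digits printed from compound 1 to compound 3 (within the scatter) is the step seen for that kind of change, the expected step is no change at the digits printed from compound 2 to compound 4 (within the scatter). Compound 4 is thus estimated at 2.5, expected to lie between 2.2 and 2.8.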

Compound 4, partition coefficient: 2.5
For compound 4 middle estimate and measured number coincide at the digits printed; the measured number falls inside the stated range.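

In this assay, trifluoromethyl in place of bromo gives no change at the digits printed from compound 2 to compound 4 (within the scatter), the same reading as no change at the digits printed from compound 1 to compound 3 (within the scatter), so across these two pairs the change carries from one core to the other, here in the place para to a large group. This rests on two pairs only, and since neither shows a step beyond the scatter, it does not show that a step of real size would carry between these cores in the same way. Nothing measured bears on why the two steps read alike.

The compounds shown carry only bromo or trifluoromethyl on the aromatic ring of the amide. Going by these compounds, whether an amine or a carboxylic acid there would read the same on both cores stays open.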